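The compounds below may be only part of what the source reports. "The series", "measured", "known", "first", "only" and "open" are said of these compounds alone.

Three compounds sharing one core have so far been examined in an ADME assay on HeLa cells (Homo sapiens) for cytotoxicity, read by sulforhodamine B assay, with a stated time of 48 h, tested at 10 uM; on this read-out higher numbers stand for more inhibition at the one concentration tested (going by the name of the read-out) and lower numbers for less inhibition. Compound 1 `COc1nc2ccc(Br)cc2cc1C(c1ccccc1)n1cc(-c2ccc(F)cc2)nn1` gives 4.27% in this assay. Compound 2 `COc1nc2ccc(Br)cc2cc1C(c1ccccc1)n1cc(CO)nn1` gives 0.25%, and compound 3 `COc1nc2ccc(Br)cc2cc1C(c1ccccc1)n1cc(-c2ccccc2)nn1` gives 13.9%. For the measured compounds named here, on these numbers compound 3 shows the highest of the three, yet its nearest neighbour, compound 1, lies a number 9.6 percentage points higher from compound 1 to compound 3 (within the scatter) apart only within the scatter, and the one step that reaches beyond the scatter is a number 13.7 percentage points higher from compound 2 to compound 3 (beyond the scatter), in which phenyl replaces hydroxymethyl on an aromatic carbon. The other step, a number 4 percentage points lower from compound 1 to compound 2 (within the scatter), stays within the scatter.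

Compound 4 `CCCc1cn(C(c2ccccc2)c2cc3cc(Br)ccc3nc2OC)nn1` is the next member, not yet measured. It differs from compound 3 in one place: propyl in place of phenyl on an aromatic carbon. The step that bears most directly on this change is the modest one from compound 2 to compound 3, where removing the phenyl from that position brought the number down; the step from compound 1 to compound 2, where a different aryl gave way to hydroxymethyl, was within the scatter. The expectation is therefore a small step downward, or none beyond the scatter, when the phenyl is exchanged for propyl: a number 6.9 percentage points lower from compound 3 to compound 4 (within the scatter) is the estimated change. Compound 4 is expected to give 7% in this assay, within a range from 0% to 16%.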

Compound 4, a percentage reported as inhibition, at one concentration (the size of the read-out at that concentration, not a potency): -2.25%
Beside the measured number, compound 4's estimate is 9.3 percentage points above it; the measured number lies below the stated range.
By their numbers in this assay, from the lowest: compounds 4, 2, 1 and 3 (each within the scatter of the next, the first and the last beyond it).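

In this assay, exchanging phenyl for propyl on this aromatic carbon of the five-membered aromatic ring with 3 nitrogen gives a number 16.2 percentage points lower from compound 3 to compound 4 (beyond the scatter). This is the second step beyond the scatter on leaving the phenyl at this carbon, so the earlier one is not peculiar to hydroxymethyl. Propyl and hydroxymethyl read alike, with a number 2.5 percentage points lower from compound 2 to compound 4 (within the scatter), and propyl also stays close to 4-fluorophenyl, with a number 6.5 percentage points lower from compound 1 to compound 4 (within the scatter), so compound 1 goes against a clean split of aryl from non-aryl groups, as it lies within the scatter of compound 3 as well as of the two non-aryl compounds. No measurement at hand says why phenyl stands apart from propyl and hydroxymethyl here.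

The compounds shown leave open whether a cyclohexyl ring at this carbon would read with the phenyl of compound 3 or with the propyl of compound 4, which would separate the presence of a ring from its being aromatic. They also leave open whether a benzyl group, a longer chain such as hexyl, or a chain ending in an amine or a carboxylic acid would move the number away from the low values seen so far.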